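Replacing the cyanosulfanyl group of compound 1

The source may hold more compounds than are shown below. What is called first, only, known or untested is meant among the compounds shown, and "the series" means these compounds.

In an ADME assay on L1210/0 cells (Mus musculus) for cytotoxicity, with a stated time of 48 h (on this read-out higher numbers stand for weaker inhibition and lower numbers for stronger inhibition), compound 1 (`N#CSc1cn([C@H]2C[C@H](O)[C@@H](CO)O2)c(=O)[nH]c1=O`) gives 78900 nM as its read-out. Compound 2 (`CC(=O)OC(C)Cn1cnc2c(Cl)nc(I)nc21`) reaches 13000 nM there, so compound 1 holds the higher of the two numbers, which means weaker inhibition. Compound 3 (`COCC#Cc1cn([C@H]2C[C@H](O)[C@@H](CO)O2)c(=O)[nH]c1=O`) carries 3-methoxyprop-1-yn-1-yl in place of cyanosulfanyl on an aromatic carbon. Among the compounds with values here, no measured pair shows this swap, so any expectation remains loose. The expected change a 1.3-fold higher number from compound 1 to compound 3 (0.10 log units; within the scatter) is estimated to stay within the usual scatter of this assay with neither direction favoured. Compound 3 is estimated at 100000 nM with an expected range (20000 nM to 500000 nM).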

Compound 3, half-maximal inhibitory concentration: > 200000 nM
Compound 3 gave a limit, no number; the forecaster's own chance of this, stated with the estimate: 35%; middle value at least 2.0-fold (0.30 log units) away from the limit.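

At this aromatic carbon, 3-methoxyprop-1-yn-1-yl in place of cyanosulfanyl gives an at least 2.5-fold higher number from compound 1 to compound 3 (0.40 log units; beyond the scatter), which means weaker inhibition in this assay. This first step at the position shows that the group placed there can change the read-out beyond the usual scatter. The read-out of compound 3 is a limit, not a number: the limit of > 200000 nM in this assay, at which 1 of the 3 values shown sits.

As far as these compounds go, whether an amine or a carboxylic acid on this carbon would inhibit more strongly than compound 1 stays open. A single step also cannot separate the effect of chain length from that of the oxygen within the chain.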